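The source may hold more compounds than are shown below. What is called first, only, known or untested is meant among the compounds shown, and "the series" means these compounds.

Compound 1 `O=C1COc2ccc(-c3[nH]c(-c4ccc(C(F)(F)F)cc4)nc3-c3ccccc3)cc2N1` gives 111% in a functional assay on MV4-11 cells (Homo sapiens) for cytotoxicity, read by colorimetric assay and MTT assay, with a stated time of 3 days, tested at 1 uM; a higher number here means a weaker effect of the compound at the concentration tested, a lower number a stronger effect.
Compound 2 `O=C1COc2ccc(-c3nn(-c4cc(Cl)cc(Cl)c4)cc3-c3ccccc3)cc2N1` gives 105% in this assay.
Compound 3 `O=C1COc2ccc(-c3nn(-c4ccccc4)cc3-c3ccccc3)cc2N1` gives 117% in this assay.

Compound 1 sits between the other two, and both neighbours lie within the scatter of it, so the three numbers show no real difference. The new compound 4 `O=C1COc2ccc(-c3[nH]c(-c4ccccc4)nc3-c3ccccc3)cc2N1` arises from compound 1 by hydrogen in place of trifluoromethyl on an aromatic carbon. For the measured compounds named here, only one measured step bears on it: a number 12 percentage points higher from compound 2 to compound 3 (beyond the scatter), where dropping ring halogens on a different part of the shared core gave a modest rise. By analogy a small rise or no step beyond the scatter is expected for compound 4, as a number 2 percentage points higher from compound 1 to compound 4 (within the scatter). Compound 4 is therefore estimated at 113%, within 100% to 126%.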

Compound 4, a percentage reported as activity, at one concentration (the size of the read-out at that concentration, not a potency): 105%
For compound 4 the middle estimate is 8 percentage points above the measured one; the range from low to high includes it.
By their numbers in this assay, from the lowest: compounds 2, 4, 1 and 3 (each within the scatter of the next, the first and the last beyond it).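

In this assay, for the compounds shown here, the change from 4-(trifluoromethyl)phenyl to phenyl gives a number 6 percentage points lower from compound 1 to compound 4 (within the scatter), so at this place, para to a large group, removing trifluoromethyl produces no step that can be told from the scatter. This differs from the earlier step on the aromatic nitrogen, a number 12 percentage points higher from compound 2 to compound 3 (beyond the scatter), which lay beyond the scatter but sits at another place on the shared core. Nothing measured here offers a reason for this result.

On these data alone, whether an amine or a carboxylic acid at this place would shift the read-out remains open. So does whether any group here could give a clear effect on these cells.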